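A few compounds are considered here, and "the series" means these few. Any claim that something is new, unique, unknown or untested is made for them only; others in the source may bear on it.

Series notes. Compound 2 `C=C(Br)C(=O)Nc1ccc(/C=C2\SC(=O)N(C)C2=O)cc1` gives 360 nM in a functional assay on CCRF-CEM cells (Homo sapiens) for cytotoxicity, read by cell counting, with a stated time of 3 days; a higher number here means a weaker inhibitor, a lower number a stronger inhibitor. Compound 1 `C=C(Br)C(=O)Nc1ccc(/C=C2\SC(=O)N(Cc3ccccc3)C2=O)cc1` gives 2300 nM in this assay; relative to compound 2 it carries phenyl in place of hydrogen on a saturated chain carbon bound to an amide-type nitrogen in a ring, and the step is a 6.4-fold higher number from compound 2 to compound 1 (0.81 log units; beyond the scatter). Compound 3 `CN1C(=O)S/C(=C\c2ccc(N)cc2)C1=O` gives 62000 nM in this assay; its difference from compound 2 is hydrogen in place of (1-bromoethenyl)carbonyl on a nitrogen on an aromatic ring, the step being a 170-fold higher number from compound 2 to compound 3 (2.24 log units; beyond the scatter), and it stands highest of the three measured. Compound 4 `Nc1ccc(/C=C2\SC(=O)N(Cc3ccccc3)C2=O)cc1` is not yet measured; relative to compound 3 it carries phenyl in place of hydrogen on a saturated chain carbon bound to an amide-type nitrogen in a ring, the same change as from compound 2 to compound 1, at the same place, on a core differing as just described. For the measured compounds named here, only one earlier instance exists, so the size may not carry over on the weaker core. Compound 4 is expected to give 200000 nM. Going by the values given here, the expected step is a 3.2-fold higher number from compound 3 to compound 4 (0.51 log units; beyond the scatter), because a 6.4-fold higher number from compound 2 to compound 1 (0.81 log units; beyond the scatter) is the sole precedent. For compound 4 the expected range runs from 60000 nM to 600000 nM.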

Compound 4, half-maximal inhibitory concentration: 42000 nM
Compound 4: middle estimate off by 4.8-fold (0.68 log units), on the high side, outside the stated range (below it).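

In this assay the change from methyl to benzyl does not carry over from one core to the other: with the (1-bromoethenyl)carbonyl group absent, the result is a 1.5-fold lower number from compound 3 to compound 4 (0.17 log units; within the scatter) and the rise seen with that group present does not appear: (the same change on two cores in this assay, a 6.4-fold higher number (0.81 log units; beyond the scatter) from compound 2 to compound 1 and a 1.5-fold lower number (0.17 log units; within the scatter) from compound 3 to compound 4, 9.4-fold (0.97 log units) apart, beyond the scatter of two such steps). Read the other way, hydrogen in place of (1-bromoethenyl)carbonyl gives an 18-fold higher number from compound 1 to compound 4 (1.26 log units; beyond the scatter) on the benzyl compounds, a smaller step than on the methyl compounds: (the same change on two cores in this assay, a 170-fold higher number (2.24 log units; beyond the scatter) from compound 2 to compound 3 and an 18-fold higher number (1.26 log units; beyond the scatter) from compound 1 to compound 4, 9.4-fold (0.97 log units) apart, beyond the scatter of two such steps). The two changes are therefore not additive across these four compounds, but this single set shows neither why nor whether it holds on any other core.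

Open, as far as these compounds go, is whether a plain acetyl or a chloroacetyl group on the nitrogen on the aromatic ring behaves like (1-bromoethenyl)carbonyl. Also open, from the compounds shown here alone, is how a longer chain such as phenylethyl compares with methyl and benzyl on either core.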